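Bromo for methoxy on the aryl end of the series

A few compounds are considered here, and "the series" means these few. Any claim that something is new, unique, unknown or untested is made for them only; others in the source may bear on it.

compound 1 `Cc1c(C(=O)/C=C/c2cccc([N+](=O)[O-])c2)[n+]([O-])c2ccccc2[n+]1[O-]` — 16300 nM
compound 2 `COc1ccc(/C=C/C(=O)c2c(C)[n+]([O-])c3ccccc3[n+]2[O-])cc1` — 25800 nM

In a functional assay on MOLT-4 cells (Homo sapiens) for inhibition, with a stated time of 3 days (a lower number here means a stronger inhibitor, a higher number a weaker inhibitor), compound 1 gives 16300 nM and compound 2 gives 25800 nM. Both numbers sit in the same high range. Among the measured compounds shown here, compound 2 carries the highest of the two numbers measured so far; its nearest neighbour is compound 1, and the gap between the two lies within the scatter, so no order between them can be read from these data. For the measured compounds named here, no pair of measured compounds differs in one place only, so there is no measured step to size what a single change on the aryl ring does in this assay.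

Compound 3 `Cc1c(C(=O)/C=C/c2ccc(Br)cc2)[n+]([O-])c2ccccc2[n+]1[O-]` differs from compound 2 by bromo in place of methoxy on an aromatic carbon; cut one bond further out, the change reads 4-methoxyphenyl to 4-bromophenyl. Going by the values given here, with no measured step of this kind to lean on, and both measured compounds sitting close together, the step from compound 2 to compound 3 is expected to be a 1.3-fold lower number from compound 2 to compound 3 (0.11 log units; within the scatter), which amounts to none beyond the scatter in either direction. Compound 3 is therefore estimated at 20000 nM, with a range from 7000 nM to 60000 nM.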

Compound 3, half-maximal inhibitory concentration: 17100 nM
Compound 3: the middle estimate sits 1.2-fold (0.07 log units) above what was measured; the range from low to high includes it.
By their numbers in this assay, from the lowest: compounds 1, 3 and 2 (each within the scatter of the next).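

In this assay the series now has its first measured step in one place: bromo in place of methoxy on an aromatic carbon, para to a large group, gives a 1.5-fold lower number from compound 2 to compound 3 (0.18 log units; within the scatter). At this position, then, 4-methoxyphenyl and 4-bromophenyl cannot be told apart in this read-out, even though the methoxy group carries a hydrogen-bond acceptor and the bromo group carries none. Nothing at hand bears on why this step stays so small.

As far as these compounds go, what remains open is whether a group of a different kind at this position, such as an amine or a carboxylic acid, would move the number beyond the scatter. Also open, from the compounds shown here alone, is whether a change elsewhere, such as a longer chain on the shared core, would do so where this exchange on the aryl end does not.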